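A Hydroxy for a Methyl on Compound 2

A few compounds are considered here, and "the series" means these few. Any claim that something is new, unique, unknown or untested is made for them only; others in the source may bear on it.

In a functional assay on HepG2 cells (Homo sapiens) for inhibition, read by WST assay, with stated times of 72 h and 2 h (a lower number here means a stronger inhibitor, a higher number a weaker inhibitor), compound 1 (`C#CCOC(c1cccs1)c1cc2ccccc2nc1Cl`) gives > 100000 nM, which is a limit of the assay and not a number. Compound 2 (`Cc1ccc(-c2cc(COC(c3cccs3)c3cc4ccccc4nc3Cl)on2)cc1`) is reported as "not active" (no number reported), so it has no single number. Compound 3 (`Oc1ccc(-c2cc(COC(c3cccs3)c3cc4ccccc4nc3Cl)on2)cc1`) is still unmeasured. The change hydroxy in place of methyl on an aromatic carbon puts hydroxy in place of methyl on an aromatic carbon, turning 4-methylphenyl into 4-hydroxyphenyl. For the measured compounds named here, no measured step gives its size, so in this assay no step beyond the scatter is expected, given compound 2 at "not active" (no number reported). Compound 3 is estimated at 100000 nM, with an expected range of 30000 nM to 200000 nM.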

Compound 3, half-maximal inhibitory concentration: 179000 nM
Compound 3: the middle estimate sits 1.8-fold (0.25 log units) below what was measured, within the range that was stated.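

No step can be read from compound 2 to compound 3, as compound 2 carries no number. The compounds shown leave open whether any other change on the shared core would give a clearly stronger inhibitor in this assay.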